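Replacing Methoxy with Chloro on Compound 3

This account rests on a few compounds, and the source may have more. Where it says the series, first, only, none or still open, it means among the compounds named here.

In a functional assay on NCI60 cells (Homo sapiens) for antiproliferative activity, read by sulforhodamine B assay, with a stated time of 48 h (on this read-out higher numbers stand for weaker inhibition of growth and lower numbers for stronger inhibition of growth), compound 1 `COc1ccc(-c2nsc3c2NC(=O)CC3c2cccc(OC)c2)cc1` gives 1550 nM, compound 2 `COc1ccc(-c2nsc3c2NC(=O)CC3c2ccc(F)cc2)cc1` gives 3020 nM and compound 3 `COc1ccc(-c2nsc3c2NC(=O)CC3c2ccsc2)cc1` gives 302 nM. Compound 3 has the lowest number of the three, and so the strongest inhibition of growth.

The measured steps all change the group on a saturated ring carbon. They are a 1.9-fold higher number from compound 1 to compound 2 (0.29 log units; within the scatter), a 5.1-fold lower number from compound 1 to compound 3 (0.71 log units; beyond the scatter) and a 10-fold lower number from compound 2 to compound 3 (1.00 log units; beyond the scatter). Compound 4 `O=C1CC(c2ccsc2)c2snc(-c3ccc(Cl)cc3)c2N1` keeps the thiophen-3-yl group of compound 3 and differs elsewhere: chloro in place of methoxy on an aromatic carbon. The chloro takes the place of methoxy on an aromatic carbon, para to a large group.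

Among the compounds with values here, no measured step touches that place, so these steps show only how far one change moved the numbers in this small set, not which way this one will go. With compound 3 already lowest at 302 nM, a small rise seems likelier than a fall. The estimated step, within the scatter, is a 1.5-fold higher number from compound 3 to compound 4 (0.17 log units; within the scatter). For compound 4 the expected value is 450 nM, with an estimated range from 130 nM to 1500 nM.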

Compound 4, concentration for 50% growth inhibition: 1510 nM
Compound 4: middle estimate off by 3.4-fold (0.53 log units), on the low side, outside the stated range (above it).
By their numbers in this assay, from the lowest: compound 3; then compounds 4, 1 and 2 (each within the scatter of the next).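

Within the data shown here, every earlier step changed the group on a saturated ring carbon, so this is the first reading of the methoxy place on the six-membered aromatic ring. In this assay, chloro in place of methoxy gives a 5.0-fold higher number from compound 3 to compound 4 (0.70 log units; beyond the scatter) with the thiophen-3-yl group held fixed, so this place matters about as much as the saturated ring carbon, where the change gave a 5.1-fold lower number from compound 1 to compound 3 (0.71 log units; beyond the scatter) in the opposite direction. Nothing available explains why the number rose with this swap.

As far as these compounds go, only methoxy and chloro are seen at this place, so it remains open how an ethoxy, a hydroxyl or an amine there would read. From the compounds shown here alone, it is also open whether the same swap would move the number as far with the 3-methoxyphenyl or 4-fluorophenyl group on the saturated ring carbon.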